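Acetyl-to-amino switch on the pendant phenyl ring

This account rests on a few compounds, and the source may have more. Where it says the series, first, only, none or still open, it means among the compounds named here.

Compound 1 `COC(=O)c1sc2cc(-c3ccsc3)cnc2c1N` — 12700 nM
Compound 2 `COC(=O)c1sc2cc(-c3ccoc3)cnc2c1N` — > 120000 nM
Compound 3 `COC(=O)c1sc2cc(-c3ccc(C(C)=O)cc3)cnc2c1N` — > 150000 nM

Compound 3 `COC(=O)c1sc2cc(-c3ccc(C(C)=O)cc3)cnc2c1N` is the acetylphenyl member of the series. In a functional assay on MCF7 cells (Homo sapiens) for inhibition, read by sulforhodamine B assay, with a stated time of 48 h (on this read-out lower numbers stand for stronger inhibition of growth and higher numbers for weaker inhibition of growth), compound 3 reaches only a limit, > 150000 nM, and no number is available for it. Compound 2 likewise gives only a limit in this assay, > 120000 nM (the limit of > 120000 nM in this assay, at which 1 of the 3 values shown sits). Going by the values given here, compound 1 is the single member with a numerical value, 12700 nM in this assay.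

Compound 4 `COC(=O)c1sc2cc(-c3ccc(N)cc3)cnc2c1N` differs from compound 3 by amino in place of acetyl on an aromatic carbon. Among the compounds with values here, the one measured step, an at least 9.4-fold higher number from compound 1 to compound 2 (0.97 log units; beyond the scatter), concerns the exchange of the whole five-membered aryl group and not a substituent on a phenyl ring, so it does not bear directly on the acetyl-to-amino change. For compound 3 itself only the limit of > 150000 nM in this assay, at which 1 of the 3 values shown sits, is known, which sets the starting point but no direction.

Within the data shown here, with no step on this kind of change, the expectation for compound 4 is drawn from compound 3 standing at its limit: the value is expected to remain weak, most likely again at or near a limit, so that the estimated step of an at least 1.5-fold lower number from compound 3 to compound 4 (0.17 log units; that floor lies within the scatter) is not expected to carry the compound into a clearly active range. Compound 4 is therefore estimated at 100000 nM in this assay, with the likely range from 20000 nM to 300000 nM.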

Compound 4, concentration for 50% growth inhibition: 108000 nM
Compound 4: the middle estimate sits 1.1-fold (0.03 log units) below what was measured; the measured number falls inside the stated range.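

A substituted phenyl at this position now has a number and not only a limit, and 4-aminophenyl in place of thiophen-3-yl gives an 8.5-fold higher number from compound 1 to compound 4 (0.93 log units; beyond the scatter), so this aryl group stays clearly weaker on growth inhibition than the thiophen-3-yl group. Amino in place of acetyl gives an at least 1.3-fold lower number from compound 3 to compound 4 (0.14 log units; that floor lies within the scatter), and 4-aminophenyl in place of furan-3-yl gives an at least 1.1-fold lower number from compound 2 to compound 4 (0.04 log units; that floor lies within the scatter); both floors lie within the scatter, so neither step shows a real gain. Compound 3 is held at a limit and not a number, so the true size of the acetyl-to-amino step remains unfixed: the limit of > 150000 nM in this assay, at which 1 of the 4 values shown sits.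

Open, on these data alone, is whether any substituent on the phenyl ring, para to a large group, can bring a phenyl member close to compound 1, which gives 12700 nM in this assay. A hydroxyl, a carboxylic acid or a dimethylamino group at that place would show whether the amino result holds for other groups on the ring, and the unsubstituted phenyl would give the reference that the acetyl and amino members lack.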